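Phenyl for 3,4-dimethoxyphenyl: working notes on compound 1

A few compounds are considered here, and "the series" means these few. Any claim that something is new, unique, unknown or untested is made for them only; others in the source may bear on it.

- compound 1 `COc1ccc(/C=C/C(=O)/C=C/c2ccc(OCc3cn(CCCCCOc4cc(=O)oc5ccccc45)nn3)c(OC)c2)cc1OC`: 45%
- compound 2 `COc1ccccc1/C=C/C(=O)/C=C/c1ccc(OCc2cn(CCCOc3cc(=O)oc4ccccc34)nn2)c(OC)c1`: 53%

In a functional assay on HCT-116 cells (Homo sapiens) for inhibition, read by sulforhodamine B assay, with a stated time of 48 h, tested at 50 uM (a lower number here means less inhibition of growth, a higher number more inhibition of growth at the concentration tested), compound 1 gives 45%, which lies within the scatter of compound 2 at 53%, so the two cannot be ranked. Compound 3 `COc1cc(/C=C/C(=O)/C=C/c2ccccc2)ccc1OCc1cn(CCCCCOc2cc(=O)oc3ccccc23)nn1` differs from compound 1 by phenyl in place of 3,4-dimethoxyphenyl on a double-bonded chain carbon bound to a double-bonded chain carbon. Within the data shown here, no measured pair isolates this change, so no step beyond the scatter is expected in this assay. The estimated step is a number 2 percentage points higher from compound 1 to compound 3 (within the scatter). The expected value for compound 3 is 47%, within an estimated range of 30% to 65%.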

Compound 3, percent growth inhibition at one concentration: 24%
Beside the measured number, compound 3's estimate is 23 percentage points above it; measured number outside the range, below it.
By their numbers in this assay, from the lowest: compound 3; then compounds 1 and 2 (each within the scatter of the next).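

With the rest of compound 1 held constant, replacing 3,4-dimethoxyphenyl with phenyl on a double-bonded chain carbon bound to a double-bonded chain carbon gives a number 21 percentage points lower from compound 1 to compound 3 (beyond the scatter) in this assay. Among these compounds, this is the first step beyond the scatter, and it shows that growth inhibition at this concentration responds to what this ring carries. Nothing at hand bears on the reason for this step.

As far as these compounds go, whether both methoxy groups are needed, or a single one would serve, remains open. So does the effect of an amine or a carboxylic acid on this phenyl ring.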